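A few compounds are considered here, and "the series" means these few. Any claim that something is new, unique, unknown or untested is made for them only; others in the source may bear on it.

Working notes on the series. Compound 1 `CCCCCCCCCCCOC(=O)NC(=O)Oc1c(C(C)C)cccc1C(C)C` gives 140 nM in an assay on microsomes from intestine for inhibition of acyl-CoA:cholesterol acyltransferase (Oryctolagus cuniculus); a higher number here means a weaker inhibitor, a lower number a stronger inhibitor. Compound 2 `CCCCCCCCCCCCCOC(=O)NC(=O)Oc1c(C(C)C)cccc1C(C)C` carries ethyl in place of hydrogen on a saturated chain carbon, ten or more bonds along the chain from an oxygen next to a carbonyl group and gives 9 nM in this assay, a step of a 16-fold lower number from compound 1 to compound 2 (1.19 log units; beyond the scatter). Compound 3 `CCCCCCCCCCC(C)OC(=O)NC(=O)Oc1c(C(C)C)cccc1C(C)C` differs from compound 1 by methyl in place of hydrogen on a saturated chain carbon bound to an oxygen next to a carbonyl group and a saturated chain carbon; in this assay compound 3 gives 49 nM, a step of a 2.9-fold lower number from compound 1 to compound 3 (0.46 log units; beyond the scatter). Compound 4 `CCCCCCCCCCCCC(C)OC(=O)NC(=O)Oc1c(C(C)C)cccc1C(C)C` has not been measured; it differs from compound 3 by ethyl in place of hydrogen on a saturated chain carbon, ten or more bonds along the chain from an oxygen next to a carbonyl group, the same change as that from compound 1 to compound 2, now made on the core of compound 3 instead of the core of compound 1. Among the measured compounds shown here, for compound 4 the expected step is a 9.8-fold lower number from compound 3 to compound 4 (0.99 log units; beyond the scatter), resting on the one measured instance of this change, a 16-fold lower number from compound 1 to compound 2 (1.19 log units; beyond the scatter). A single instance leaves the size of the step uncertain. Compound 4 is therefore estimated at 5 nM in this assay, with a range from 1.5 nM to 15 nM.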

Compound 4, half-maximal inhibitory concentration: 17 nM
Compound 4: middle estimate off by 3.4-fold (0.53 log units), on the low side, outside the stated range (above it).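

The ethyl change gives a 2.9-fold lower number from compound 3 to compound 4 (0.46 log units; beyond the scatter) in this assay, and its size does not carry over from one core to the other: the same change on two cores in this assay, a 16-fold lower number (1.19 log units; beyond the scatter) from compound 1 to compound 2 and a 2.9-fold lower number (0.46 log units; beyond the scatter) from compound 3 to compound 4, 5.4-fold (0.73 log units) apart, beyond the scatter of two such steps. The methyl change gives a 1.9-fold higher number from compound 2 to compound 4 (0.28 log units; within the scatter), a step within the scatter, and it does not carry over either: the same change on two cores in this assay, a 2.9-fold lower number (0.46 log units; beyond the scatter) from compound 1 to compound 3 and a 1.9-fold higher number (0.28 log units; within the scatter) from compound 2 to compound 4, 5.4-fold (0.73 log units) apart, beyond the scatter of two such steps. The two changes therefore do not add up across these four compounds; the ethyl step keeps its direction on both cores but not its size, and these data do not show why.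

Among the compounds shown here, each change has been seen on only two cores, so its behaviour on any other core stays open. On these data alone, how a longer chain or an amine would behave in this assay also stays open.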